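Swapping One Ring on a Soluble Compound

A few compounds are considered here, and "the series" means these few. Any claim that something is new, unique, unknown or untested is made for them only; others in the source may bear on it.

In a physicochemical assay for solubility, read by HPLC, in phosphate buffer, at pH 6.5 (a higher number here means a more soluble compound, a lower number a less soluble compound), compound 1 (`COC(=O)C1=C(C)NC(c2nccs2)=NC1(C)c1ccc(F)c(F)c1`) gives 50 ug/mL and compound 2 (`COC(=O)C1=C(CN2CCCCC2)NC(c2nccs2)=NC1(C)c1ccc(F)cc1`) gives 282 ug/mL as the higher of the two numbers, a gap beyond the usual scatter. Compound 3 (`COC(=O)C1=C(CN2CCOCC2=O)NC(c2nccs2)=NC1(C)c1ccc(F)cc1`) is compound 2 with one change, on a saturated chain carbon bound to a double-bonded ring carbon (3-oxomorpholin-4-yl in place of piperidin-1-yl on a saturated chain carbon bound to a double-bonded ring carbon). Among the compounds with values here, no measured pair shows this exchange, so any forecast is rough. The expected change in this assay is a fall, estimated as a 3.5-fold lower number from compound 2 to compound 3 (0.55 log units; beyond the scatter) and so beyond the scatter. For compound 3 the estimate is 80 ug/mL with an expected range from 25 ug/mL to 250 ug/mL in this measurement.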

Compound 3, solubility: 440 ug/mL
For compound 3 the middle estimate is 5.5-fold (0.74 log units) below the measured one; measured number above the stated range.
By their numbers in this assay, from the lowest: compound 1; then compounds 2 and 3 (each within the scatter of the next).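

In this assay the exchange of piperidin-1-yl for 3-oxomorpholin-4-yl on a saturated chain carbon bound to a double-bonded ring carbon gives a 1.6-fold higher number from compound 2 to compound 3 (0.19 log units; within the scatter) and so leaves the two compounds indistinguishable. This position therefore accepts a quite different ring, one carrying a carbonyl and a second hetero atom, with no step beyond the scatter, which compound 1 and compound 2 could not show. Nothing measured here explains this result. The compounds shown leave open how a plain morpholin-4-yl group or a carboxylic acid would read at this place, and so whether the carbonyl of the 3-oxomorpholin-4-yl group matters at all.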